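Prenyl ether to aryl carbamate on the pyridinone oxygen

The source may hold more compounds than are shown below. What is called first, only, known or untested is meant among the compounds shown, and "the series" means these compounds.

Working notes on the series. Compound 2 `CC(C)=CCOc1cc(=O)n(CCCO)c2c1CC(CC=C(C)C)C(C)(C)C2` gives 20.7% in a functional assay on PANC-1 cells (Homo sapiens) for inhibition, read by MTT assay, with a stated time of 24 h, tested at 10 uM (a lower number here means less inhibition, a higher number more inhibition at the concentration tested (going by the name of the read-out)), the lowest of the three numbers in hand. Compound 1 `CC(C)=CCC/C(C)=C/CC1Cc2c(O)cc(=O)n(CCCO)c2CC1(C)C` gives 28.7%, which lies within the scatter of compound 2. Compound 3 `COc1ccc(C(=O)NCCCOc2cc(=O)n(CCCO)c3c2CC(CC=C(C)C)C(C)(C)C3)cc1` gives 55.5%, beyond the scatter above compound 2. Among the compounds with values here, no step between measured compounds differs in a single place, so nothing measured maps directly onto the change to compound 4 `CC(C)=CCC1Cc2c(OC(=O)Nc3ccc(F)cc3)cc(=O)n(CCCO)c2CC1(C)C`. The change is (4-fluorophenyl)carbamoyl in place of 3-methylbut-2-en-1-yl on an oxygen on an aromatic ring. Because compound 3 shows 55.5% with an aromatic amide attached through that same oxygen, the step of a number 24.3 percentage points higher from compound 2 to compound 4 (beyond the scatter) is expected to be upward and beyond the scatter. Compound 4 is estimated at 45%, ranging from 25% to 65%.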

Compound 4, a percentage reported as inhibition, at one concentration (the size of the read-out at that concentration, not a potency): 71.2%
The estimate for compound 4 lay 26.2 percentage points below the measured number, and the stated range ends below it.
By their numbers in this assay, from the lowest: compounds 2 and 1 (each within the scatter of the next); then compound 3; then compound 4.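

In this assay, within the data shown here, the oxygen on an aromatic ring proves to be a position where one change alone moves the read-out: (4-fluorophenyl)carbamoyl in place of 3-methylbut-2-en-1-yl gives a number 50.5 percentage points higher from compound 2 to compound 4 (beyond the scatter) and is the only single-place step available. The shared core and the 3-hydroxypropyl chain on the ring nitrogen stay the same across this step. Nothing in hand accounts for the size of this step. As far as these compounds go, whether it follows from the carbamoyl linker or the 4-fluorophenyl ring remains open. An unsubstituted phenylcarbamoyl or a methylcarbamoyl group on this oxygen would separate the two.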